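Morpholin-4-yl to methylamino on compound 1

A few compounds are considered here, and "the series" means these few. Any claim that something is new, unique, unknown or untested is made for them only; others in the source may bear on it.

Measured in an in vitro ADME assay on microsomes from liver (Macaca fascicularis) for metabolic stability (on this read-out lower numbers stand for slow clearance and higher numbers for fast clearance), so far:
- compound 1 `CC[C@H](C)[C@@H]1C(=O)N[C@H](C2Cc3ccccc3C2)C(=O)N1[C@@H](C(=O)N1CCOCC1)c1cnc(C)cc1C` gives 16 mL.min-1.g-1
- compound 2 `CCC(CC)[C@@H]1C(=O)N[C@H](C2Cc3ccccc3C2)C(=O)N1[C@@H](C(=O)N1CCOCC1)c1ccc(C)nc1` gives 18 mL.min-1.g-1

Among the measured compounds shown here, compound 1 and compound 2 lie within the scatter of each other, so compound 1 stands level with the only other measured compound. Compound 3 `CC[C@H](C)[C@@H]1C(=O)N[C@H](C2Cc3ccccc3C2)C(=O)N1[C@@H](C(=O)NC)c1cnc(C)cc1C` keeps the core of compound 1 and carries methylamino in place of morpholin-4-yl on a carbonyl carbon in its structure. For the measured compounds named here, no measured step covers this change, so the expectation in this assay is tentative: a small move toward slower clearance, probably within the scatter. The expected change is a 1.3-fold lower number from compound 1 to compound 3 (0.12 log units; within the scatter) on this estimate. For compound 3 the estimated value is 12 mL.min-1.g-1 with an expected range of 5 mL.min-1.g-1 to 28 mL.min-1.g-1 for now.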

Compound 3, intrinsic clearance in microsomes: 20 mL.min-1.g-1
Estimate against measurement, compound 3: 1.7-fold (0.22 log units) below, within the range that was stated.
By their numbers in this assay, from the lowest: compounds 1, 2 and 3 (each within the scatter of the next).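

In this assay, methylamino in place of morpholin-4-yl on a carbonyl carbon gives a 1.3-fold higher number from compound 1 to compound 3 (0.10 log units; within the scatter), so the read-out does not separate these two groups on the core of compound 1. The step removes the ring, replaces 6 heavy atoms with 2 and adds 1 hydrogen-bond donor, yet stays within the scatter. Nothing available explains this level result.

Still open, as far as these compounds go, is how a carboxylic acid or piperidin-1-yl on that carbonyl carbon would read. Also open, from the compounds shown here alone, is whether the same step would stay within the scatter on the core of compound 2.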